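This account rests on a few compounds, and the source may have more. Where it says the series, first, only, none or still open, it means among the compounds named here.

Compound 3 `Cn1c(-c2ccc(NC(=O)CSc3nc4ccccc4s3)cc2)nc(-c2ccccc2)c1-c1ccccc1` sits in the middle of the three compounds measured in a functional assay on HT-29 cells (Homo sapiens) for cytotoxicity, read by MTT assay, with a stated time of 24 h, tested at 0.64 ug/mL; a lower number here means a weaker effect, a higher number a stronger effect of the compound at the concentration tested. Compound 3 gives 9.8%. Compound 1 `Cn1c(-c2ccc(NC(=O)CCl)cc2)nc(-c2ccccc2)c1-c1ccccc1` gives 7.2%, and the two values lie within the usual scatter of each other. Going by the values given here, compound 2 `Cn1c(-c2ccc(NC(=O)CSc3nc4ccccc4o3)cc2)nc(-c2ccccc2)c1-c1ccccc1` gives 24.8%, so the step of a number 15 percentage points lower from compound 2 to compound 3 (beyond the scatter) is the only one around compound 3 that is beyond the scatter. Compound 4 `Cn1cnnc1SCC(=O)Nc1ccc(-c2nc(-c3ccccc3)c(-c3ccccc3)n2C)cc1` differs from compound 3 in one place: 4-methyl-4H-1,2,4-triazol-3-yl in place of 1,3-benzothiazol-2-yl on a sulfur. The group on that sulfur has been exchanged once before, in a number 15 percentage points lower from compound 2 to compound 3 (beyond the scatter), with only a modest effect, and the step of a number 2.6 percentage points higher from compound 1 to compound 3 (within the scatter) at the saturated chain carbon bound to a carbonyl carbon stayed within the scatter. Among the compounds with values here, no measured compound carries a 4-methyl-4H-1,2,4-triazol-3-yl on this sulfur. Compound 4 is therefore expected to show a step of a number 1.2 percentage points higher from compound 3 to compound 4 (within the scatter), within the scatter, with an estimated 11% and a range of 3% to 25%.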

Compound 4, a percentage reported as activity, at one concentration (the size of the read-out at that concentration, not a potency): 32%
Estimate against measurement, compound 4: 21 percentage points below; the measured number lies above the stated range.
By their numbers in this assay, from the lowest: compounds 1 and 3 (each within the scatter of the next); then compounds 2 and 4 (each within the scatter of the next).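

On this sulfur, 4-methyl-4H-1,2,4-triazol-3-yl in place of 1,3-benzothiazol-2-yl gives a number 22.2 percentage points higher from compound 3 to compound 4 (beyond the scatter), the largest change yet seen from swapping this group alone. The (4-methyl-4H-1,2,4-triazol-3-yl)sulfanyl group in place of chloro gives a number 24.8 percentage points higher from compound 1 to compound 4 (beyond the scatter), whereas (1,3-benzothiazol-2-yl)sulfanyl stayed within the scatter of chloro. Against 1,3-benzoxazol-2-yl the triazolyl group gives a number 7.2 percentage points higher from compound 2 to compound 4 (within the scatter), so a single five-membered ring on this sulfur matches a fused pair of rings.

Nothing available explains why these groups differ. From the compounds shown here alone, it remains open how an amine or a carboxylic acid in place of the chloro would read.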